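Working notes on substituents carried by the ring amine nitrogen

This account rests on a few compounds, and the source may have more. Where it says the series, first, only, none or still open, it means among the compounds named here.

Measured compounds and values:
- compound 1 `C=CCN1CCC(CCCn2c(COc3ccccc3)nc3c(OCCCN4CCCCC4)cccc32)CC1`: in an in vitro assay on AV12 cells for binding affinity to Neuropeptide Y receptor type 1 (Homo sapiens) (a lower number here means a stronger inhibitor, a higher number a weaker inhibitor), compound 1 gives 1.63 nM
- compound 2 `CC(C)CCN1CCC(CCCn2c(COc3ccccc3)nc3c(OCCCN4CCCCC4)cccc32)CC1`: in this assay compound 2 gives 0.29 nM
- compound 3 `c1ccc(CCCN2CCC(CCCn3c(COc4ccccc4)nc4c(OCCCN5CCCCC5)cccc43)CC2)cc1`: in this assay compound 3 gives 0.361 nM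

Compound 3 stands second highest of the three numbers, close to compound 2 and well apart from compound 1. Among the measured compounds shown here, the steps so far read a 5.6-fold lower number from compound 1 to compound 2 (0.75 log units; beyond the scatter) and a 4.5-fold lower number from compound 1 to compound 3 (0.65 log units; beyond the scatter), while a 1.2-fold higher number from compound 2 to compound 3 (0.10 log units; within the scatter).

Compound 4 `O=C(CCCN1CCC(CCCn2c(COc3ccccc3)nc3c(OCCCN4CCCCC4)cccc32)CC1)c1ccccc1` carries the change (benzoyl in place of phenyl on a saturated chain carbon, three bonds along the chain from an amine nitrogen in a ring). For the measured compounds named here, no measured step touches this position; the only nearby comparison, the step from compound 2 to compound 3, lies within the scatter. A step no larger than the scatter is therefore expected, direction undecided, so the expected step is a 1.2-fold higher number from compound 3 to compound 4 (0.10 log units; within the scatter). Compound 4 is estimated at 0.45 nM, with a range from 0.15 nM to 1.3 nM.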

Compound 4, inhibition constant: 0.132 nM
Compound 4: the middle estimate sits 3.4-fold (0.53 log units) above what was measured; the measured number lies below the stated range.
By their numbers in this assay, from the lowest: compound 4; then compounds 2 and 3 (each within the scatter of the next); then compound 1.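

In this assay, 3-benzoylpropyl in place of 3-phenylpropyl gives a 2.7-fold lower number from compound 3 to compound 4 (0.44 log units; beyond the scatter), so this position still responds to change when the substituent already carries an aromatic ring, which the step between compound 2 and compound 3 did not show. The new substituent also stands apart from the earlier ones, with a 2.2-fold lower number from compound 2 to compound 4 (0.34 log units; beyond the scatter) and a 12-fold lower number from compound 1 to compound 4 (1.09 log units; beyond the scatter), the latter being the largest step in the series. Nothing at hand accounts for this gain.

Still open, as far as these compounds go, is whether the carbonyl itself or the added length of the substituent carries the step: a hydroxyl in place of the carbonyl, or a longer chain ending in benzoyl, would separate the two.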